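The source may hold more compounds than are shown below. What is called first, only, known or untested is meant among the compounds shown, and "the series" means these compounds.

Measured in a functional assay on MDA-MB-231 cells (Homo sapiens) for inhibition, read by MTT assay, with a stated time of 72 h; on this read-out higher numbers stand for weaker inhibition and lower numbers for stronger inhibition:
compound 1 `O=C(CSc1nc(Nc2ccccc2)c2ccccc2n1)Nc1cccc(Cl)c1` gives 16500 nM
compound 2 `O=C(CSc1nc(Nc2ccccc2)c2ccccc2n1)Nc1cccc(Br)c1` gives 17500 nM
compound 3 `C=CC(=O)Nc1cccc(NC(=O)CSc2nc(Nc3cccc(Cl)c3)c3ccccc3n2)c1` gives 16300 nM

Compound 1 and compound 2 share a core and differ in one place, (bromo in place of chloro on an aromatic carbon). The resulting step, a 1.1-fold higher number from compound 1 to compound 2 (0.03 log units; within the scatter), is small. Compound 3 carries another core; the difference between the two cores is not broken down here. Compound 4 `C=CC(=O)Nc1cccc(NC(=O)CSc2nc(Nc3cccc(Br)c3)c3ccccc3n2)c1` has not yet been measured in this assay. It differs from compound 3 by the same change at the same place, (bromo in place of chloro on an aromatic carbon). Within the data shown here, the only available precedent for this change is the step from compound 1 to compound 2. The step expected from compound 3 to compound 4, a 1.1-fold higher number from compound 3 to compound 4 (0.03 log units; within the scatter), is estimated to be of about that size, resting on a 1.1-fold higher number from compound 1 to compound 2 (0.03 log units; within the scatter). Compound 4 is therefore expected to give about 17500 nM in this assay, estimated to fall between 11000 nM and 28000 nM.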

Compound 4, half-maximal inhibitory concentration: 19400 nM
For compound 4 the middle estimate is 1.1-fold (0.04 log units) below the measured one, within the range that was stated.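

In this assay, bromo in place of chloro, read here as 3-chlorophenyl to 3-bromophenyl, gives a 1.2-fold higher number from compound 3 to compound 4 (0.08 log units; within the scatter), so the step on this core is also small. No difference between the two cores can be read from this change: the same change on two cores in this assay, a 1.1-fold higher number (0.03 log units; within the scatter) from compound 1 to compound 2 and a 1.2-fold higher number (0.08 log units; within the scatter) from compound 3 to compound 4, 1.1-fold (0.05 log units) apart, within the scatter of two such steps

Among these compounds, this rests on only two pairs, and neither step lies beyond the scatter, so it shows that this swap leaves the number essentially unmoved on both cores, not that a change with a larger step would carry over in the same way. The compounds shown leave open whether a smaller or differently built group in place of the halogen, such as fluoro, methoxy or an amine, would move the number on either core.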